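From tert-butyl to phenyl: a step against a limit

The compounds below may be only part of what the source reports. "The series", "measured", "known", "first", "only" and "open" are said of these compounds alone.

Of the compounds shown here, three on the shared core have so far been read in a toxicity assay on MDCK cells (Canis lupus familiaris) for cytotoxicity, read by CCK-8 assay, with a stated time of 48 h (a higher number here means that more compound is tolerated, a lower number that less compound is tolerated), and none of them gives a number. Compound 1 `CCc1ccc(C(=O)NNc2c(Br)cccc2Br)cc1` gives > 100000 nM as a limit and not a number. Compound 2 `CC(C)(C)c1ccc(C(=O)NNc2c(Br)cccc2Br)cc1` gives > 100000 nM as a limit as well. Compound 3 `O=C(NNc1c(Br)cccc1Br)c1ccc2ccccc2c1` gives > 100000 nM as a limit too. The whole set rests on the limit of > 100000 nM in this assay, at which 3 of the 3 values shown sit, and so compound 2 has only a limit to stand on, with both other values being limits of the same kind.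

Compound 4 `O=C(NNc1c(Br)cccc1Br)c1ccc(-c2ccccc2)cc1` has not been measured. Its difference from compound 2 is phenyl in place of tert-butyl on an aromatic carbon and in words this is phenyl in place of tert-butyl on an aromatic carbon, para to a large group. Among the measured compounds shown here, the one measured step that bears on this change is a step that the two limits leave unreadable from compound 1 to compound 2 and it offers no size to carry over. Resting on compound 2 at > 100000 nM as a limit, no step beyond the scatter is expected in this assay in either direction. The estimated step is a number no higher from compound 2 to compound 4 (the limit leaves the size open) on this reading. For compound 4 the estimate is 100000 nM with an expected range from 50000 nM to 200000 nM and a reading at the limit is the likeliest outcome.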

Compound 4, half-maximal cytotoxic concentration: 84100 nM
Compound 4: the middle estimate sits 1.2-fold (0.08 log units) above what was measured; measured number inside the range.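

With phenyl in place of tert-butyl on an aromatic carbon, para to a large group, compound 4 is the only compound shown that gives a number rather than a limit in this assay, at 84100 nM. Read against the earlier compounds, this change gives an at least 1.1-fold lower number from compound 2 to compound 4 (0.07 log units; that floor lies within the scatter), and phenyl in place of ethyl gives an at least 1.1-fold lower number from compound 1 to compound 4 (0.07 log units; that floor lies within the scatter), so each step is a floor and not a full size. The position can therefore carry a group with which the read-out falls inside the range of the assay, but the rest of the set offers no second number to set beside it: the limit of > 100000 nM in this assay, at which 3 of the 4 values shown sit.

From the compounds shown here alone, neither step can yet be said to go beyond the scatter, and how much lower the number for compound 4 lies than those of the compounds it is compared with stays open. Going by these compounds, it is also open how this assay would respond at this position to an amine, a carboxylic acid or a longer chain, so one number on a carbon-only aromatic ring supports no trend across groups.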